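Nitrophenyl for chlorophenyl on the aromatic nitrogen

The source may hold more compounds than are shown below. What is called first, only, known or untested is meant among the compounds shown, and "the series" means these compounds.

compound 1 `COc1cc(C(=O)c2cn(-c3ccccc3[N+](=O)[O-])cc2-c2ccccc2)cc(OC)c1OC`: 5000 nM
compound 2 `COc1cc(C(=O)c2cn(-c3cccc(Cl)c3)cc2-c2ccccc2)cc(OC)c1OC`: 150 nM

In a functional assay on MCF7 cells (Homo sapiens) for cytotoxicity, read by MTT assay, with a stated time of 96 h (a lower number here means a stronger inhibitor, a higher number a weaker inhibitor), compound 2 stands lowest of the two at 150 nM. The unmeasured compound 3 `COc1cc(C(=O)c2cn(-c3ccc([N+](=O)[O-])cc3)cc2-c2ccccc2)cc(OC)c1OC` differs from it as follows: 4-nitrophenyl in place of 3-chlorophenyl on an aromatic nitrogen That is, 4-nitrophenyl in place of 3-chlorophenyl on an aromatic nitrogen. Among the measured compounds shown here, one measured step bears on this, a 33-fold lower number from compound 1 to compound 2 (1.52 log units; beyond the scatter), and it is large. It involves 2-nitrophenyl, not 4-nitrophenyl, so it guides only in part. A rise in this assay smaller than that step is expected, an estimated 5.3-fold higher number from compound 2 to compound 3 (0.73 log units; beyond the scatter). For compound 3 the expected value is 800 nM, with an estimated range of 200 nM to 3500 nM.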

Compound 3, half-maximal inhibitory concentration: 4000 nM
For compound 3 the middle estimate is 5.0-fold (0.70 log units) below the measured one, and the stated range ends below it.
By their numbers in this assay, from the lowest: compound 2; then compounds 3 and 1 (each within the scatter of the next).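

In this assay, 4-nitrophenyl in place of 3-chlorophenyl gives a 27-fold higher number from compound 2 to compound 3 (1.43 log units; beyond the scatter), so the poor result is not peculiar to 2-nitrophenyl. The two nitrophenyl compounds are not separated (a 1.3-fold lower number from compound 1 to compound 3 (0.10 log units; within the scatter)), and among these three compounds only 3-chlorophenyl stands apart. No measured property accounts for this gap.

On these data alone, whether the chlorine itself or its place on the ring matters remains open. So does how 4-chlorophenyl, 3-nitrophenyl or an aminophenyl group on the same nitrogen would read.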